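Methyl on the sulfonamide nitrogen of compound 2

The source may report more compounds than this note shows. Statements on the series, on what has been measured and on what is new or still open speak of the compounds shown alone.

In a physicochemical assay for solubility, with a stated time of 24 h, tested at 30 mg/mL (a higher number here means a more soluble compound, a lower number a less soluble compound), compound 1 (`Cc1cc(COc2ccc(S(=O)(=O)NC3(C(=O)NO)CC3)cc2)c2ccccc2n1`) gives 46000000 nM and compound 2 (`Cc1cc(COc2ccc(S(=O)(=O)NC3(C(=O)NO)CN(C(=O)C(C)C)C3)cc2)c2ccccc2n1`) gives 17000000 nM as the lower of the two numbers, with a gap beyond the scatter. For the measured compounds named here, compound 3 (`Cc1cc(COc2ccc(S(=O)(=O)N(C)C3(C(=O)NO)CN(C(=O)C(C)C)C3)cc2)c2ccccc2n1`) carries methyl in place of hydrogen on a sulfonamide nitrogen and no measured pair shows this change. The expectation is therefore only tentative. A small fall no larger than the scatter is expected in this assay (a 1.4-fold lower number from compound 2 to compound 3 (0.15 log units; within the scatter)). The estimated value for compound 3 is 12000000 nM (4000000 nM to 40000000 nM).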

Compound 3, solubility: 56000000 nM
Compound 3: middle estimate off by 4.7-fold (0.67 log units), on the low side, outside the stated range (above it).
By their numbers in this assay, from the lowest: compound 2; then compounds 1 and 3 (each within the scatter of the next).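

In this assay, for the compounds shown here, methyl in place of hydrogen on a sulfonamide nitrogen gives a 3.3-fold higher number from compound 2 to compound 3 (0.52 log units; beyond the scatter), the first measured step at this position. The read-out therefore responds to this nitrogen, and the hydrogen there is not required for a high number in this pair. No measurement available bears on the cause of the step.

From the compounds shown here alone, it remains open whether an ethyl group or a longer chain ending in an amine or a carboxylic acid would follow methyl at this nitrogen. Also open, going by these compounds, is whether the same change would give a similar step on the core of compound 1.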